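Methylcarbamoyl addition on the aryl ring of compound 1

The source may report more compounds than this note shows. Statements on the series, on what has been measured and on what is new or still open speak of the compounds shown alone.

Measured compounds in a functional assay on NCI-H460 cells (Homo sapiens) for antiproliferative activity, with a stated time of 72 h; a higher number here means a weaker inhibitor, a lower number a stronger inhibitor:
compound 1 `C=CC[C@H]1C[C@]2([C@@H](C)Cc3ccc(OC)cc3)OCOC2=CC1=O` gives 90 nM;
compound 2 `C=CC[C@H]1C[C@]2([C@H](C)Cc3ccc(OC)cc3)OCOC2=CC1=O` gives 120 nM;
compound 3 `C=CC[C@H]1C[C@]2([C@@H](C)Cc3cccc(OC)c3)OCOC2=CC1=O` gives 10600 nM.

Compound 1 holds the lowest of the three numbers. Compound 2 differs from it only in configuration as drawn, and the step of a 1.3-fold higher number from compound 1 to compound 2 (0.12 log units; within the scatter) lies within the scatter; given (the fact that compounds 1 and 2 differ only in the configuration as drawn), the two are read as one result. Compound 3 carries a 3-methoxyphenyl in place of the 4-methoxyphenyl, and the step of a 120-fold higher number from compound 1 to compound 3 (2.07 log units; beyond the scatter) is large. Among these three compounds, the placement of the methoxy group on the aromatic ring is the one change that moves the number.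

Compound 4 `C=CC[C@H]1C[C@]2([C@@H](C)Cc3ccc(OC)c(C(=O)NC)c3)OCOC2=CC1=O` keeps the 4-methoxyphenyl and adds (methylcarbamoyl in place of hydrogen on an aromatic carbon). For the measured compounds named here, no measured step adds a group to this ring, so the only guidance is the large loss in the step of a 120-fold higher number from compound 1 to compound 3 (2.07 log units; beyond the scatter), which shows that altering the aromatic substitution pattern can cost much. A loss is therefore expected, of uncertain size, and the expected step is a 5.6-fold higher number from compound 1 to compound 4 (0.74 log units; beyond the scatter). For compound 4 the estimate in this assay is 500 nM, with a range from 120 nM to 3000 nM.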

Compound 4, half-maximal inhibitory concentration: 1100 nM
The estimate for compound 4 lay 2.2-fold (0.34 log units) below the measured number; low and high end bracket the measured number.
By their numbers in this assay, from the lowest: compounds 1 and 2 (each within the scatter of the next); then compound 4; then compound 3.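

In this assay, methylcarbamoyl in place of hydrogen on an aromatic carbon, ortho to a methoxy group, gives a 12-fold higher number from compound 1 to compound 4 (1.09 log units; beyond the scatter). The earlier compounds shown here showed a cost only for moving the methoxy group; here the 4-methoxyphenyl stays in place and adding a group at this position alone still gives a large step, so keeping that methoxy group does not by itself hold the number at the level of compound 1. Nothing on hand explains this step.

Going by these compounds, whether the step belongs to methylcarbamoyl in particular or to any group at this position stays open, and a fluorine, a methyl, a carboxylic acid or an aminomethyl group there would test this. Also open, on these data alone, is whether the chain configuration, which makes no readable difference between compound 1 and compound 2, stays without effect once methylcarbamoyl is present.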